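Replacing the carboxy group of compound 2 with hydroxy

The source may report more compounds than this note shows. Statements on the series, on what has been measured and on what is new or still open speak of the compounds shown alone.

In a functional assay on HeLa cells (Homo sapiens) for antiproliferative activity, read by CCK-8 assay, with a stated time of 48 h (on this read-out lower numbers stand for stronger inhibition and higher numbers for weaker inhibition), compound 1 `COc1ccc(/C=C\c2cc(OC)c(OC)c(OC)c2)cc1OCc1ccc(CN2CCCC[C@H]2C(=O)O)cc1` gives > 10000 nM, which is a limit of the assay and not a number. Among the measured compounds shown here, compound 2 `COc1ccc(/C=C\c2cc(OC)c(OC)c(OC)c2)cc1OCc1ccc(CN2CC[C@@H](C(=O)O)C2)cc1` gives 12800 nM, the only true number available so far. For the measured compounds named here, the one measured step, a step that the limit leaves unreadable from compound 1 to compound 2, therefore offers no size to build on, and no measured step covers the change that comes next.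

Compound 3 `COc1ccc(/C=C\c2cc(OC)c(OC)c(OC)c2)cc1OCc1ccc(CN2CC[C@@H](O)C2)cc1` differs from compound 2 at a single place, with hydroxy in place of carboxy on a saturated ring carbon, so that 3-carboxypyrrolidin-1-yl becomes 3-hydroxypyrrolidin-1-yl (hydroxy in place of carboxy on a saturated ring carbon). Both measured compounds carry a carboxy group, and compound 2 at 12800 nM shows only weak inhibition with that group in place. Losing the carboxy group is therefore expected to move the value toward stronger inhibition, though this is a judgement without a measured precedent. The expected change is a 26-fold lower number from compound 2 to compound 3 (1.41 log units; beyond the scatter), well beyond the usual scatter. For compound 3 the estimated value is 500 nM, with an expected range of 30 nM to 8000 nM.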

Compound 3, half-maximal inhibitory concentration: > 10000 nM
Compound 3: no number, only a limit; the forecaster's own chance of this, stated with the estimate: 10%; at least 20-fold (1.30 log units) between middle value and limit.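

In this assay compound 3 gives > 10000 nM, which is a limit of the assay and not a number. No step from compound 2 or compound 1 to compound 3 can be read, because the values stop at this limit: the limit of > 10000 nM in this assay, at which 2 of the 3 values shown sit.

The compounds shown leave open whether 3-hydroxypyrrolidin-1-yl or 3-carboxypyrrolidin-1-yl gives the stronger inhibition, and by how much.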